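A few compounds are considered here, and "the series" means these few. Any claim that something is new, unique, unknown or untested is made for them only; others in the source may bear on it.

Compound 1 `Nc1nc(NCCNc2ncc(-c3ncc[nH]3)c(-c3ccc(C(F)(F)F)cc3)n2)ccc1[N+](=O)[O-]` is tested in an ADME assay on microsomes from liver (Rattus norvegicus) for metabolic stability (a higher number here means that the compound lasts longer, a lower number that the compound disappears faster), where compound 1 gives > 0.5 h, which is a limit of the assay rather than a number. Compound 2 `Nc1nc(NCCNc2ncc(-c3ncc[nH]3)c(-c3ccc(F)cc3Br)n2)ccc1[N+](=O)[O-]` gives > 0.5 h in this assay, also a limit. Compound 3 `Nc1nc(NCCNc2ncc(-c3ncc[nH]3)c(-c3cc(F)c(Cl)cc3F)n2)ccc1[N+](=O)[O-]` gives > 0.5 h in this assay, again a limit. All three values sit at the limit of > 0.5 h in this assay, at which 3 of the 3 values shown sit, so the steps a step that the two limits leave unreadable from compound 1 to compound 2, a step that the two limits leave unreadable from compound 1 to compound 3 and a step that the two limits leave unreadable from compound 2 to compound 3 cannot be read, and compound 1 cannot be placed above or below the other two. Compound 4 `Cc1cc(Cl)ccc1-c1nc(NCCNc2ccc([N+](=O)[O-])c(N)n2)ncc1-c1ncc[nH]1` differs from compound 1 by 4-chloro-2-methylphenyl in place of 4-(trifluoromethyl)phenyl on an aromatic carbon. The measured steps that bear on this change give no readable size, so no step beyond the scatter is expected from a step that the limit leaves unreadable from compound 1 to compound 4. Compound 4 is expected to give 0.6 h in this assay, somewhere between 0.3 h and 1.5 h, most likely reported again only as a limit.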

Compound 4, half-life: > 0.5 h
Compound 4 gave a limit, no number; the forecaster's own chance of this, stated with the estimate: 85%; the middle value lies beyond the limit too.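

Compound 4 sits at the same limit in this assay as compound 1, compound 2 and compound 3, so none of its steps to those three can be read: the limit of > 0.5 h in this assay, at which 4 of the 4 values shown sit.

The compounds shown leave open how long each one actually lasts, and whether their different phenyl groups change that at all.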